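The compounds below may be only part of what the source reports. "The series", "measured", "known", "first", "only" and "open" are said of these compounds alone.

Compound 1 `CCc1ccc(-c2c(-c3nn(C)c4ncnc(N5CCN(C)CC5)c34)cnn2C)cc1` gives 60 mL/min/kg in an ADME assay on microsomes from liver (Homo sapiens) for metabolic stability; on this read-out lower numbers stand for slow clearance and higher numbers for fast clearance.
Compound 2 `Cn1ncc(-c2nn(C)c3ncnc(N4CCC4)c23)c1-c1ccccc1` gives 34 mL/min/kg in this assay.
Compound 3 `COc1ccccc1CCOc1cncc2nnc(CC(C)C)n12` reaches only a limit of the assay in this assay, reported as > 287 mL/min/kg, which is a limit and not a number (the limit of > 287 mL/min/kg in this assay, at which 1 of the 3 values shown sits).

Of the two numbers shown, compound 2 stands lowest in this assay, and compound 1 comes nearest to it with a gap that lies within the usual scatter, so no order between the two is claimed. Compound 4 `Cn1ncc(-c2nn(C)c3ncnc(N4CCC4)c23)c1-c1ccc(C2CC2)cn1` has not been measured in this assay. It differs from compound 2 in one place: 5-cyclopropylpyridin-2-yl in place of phenyl on an aromatic carbon. No measured pair among the compounds shown makes this kind of change, so nothing here tells how large such a step tends to be. The account therefore expects the step of a 1.2-fold higher number from compound 2 to compound 4 (0.09 log units; within the scatter) to stay within the scatter, with at most a slight lean toward faster clearance. For compound 4 the estimate in this assay is 42 mL/min/kg, with a range from 18 mL/min/kg to 95 mL/min/kg.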

Compound 4, clearance: 53 mL/min/kg
The estimate for compound 4 lay 1.3-fold (0.10 log units) below the measured number, within the range that was stated.
By their numbers in this assay, from the lowest: compounds 2, 4 and 1 (each within the scatter of the next). At a limit, above all of these: compound 3.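

Among the compounds shown here, the exchange of phenyl for 5-cyclopropylpyridin-2-yl gives the first step that can be read at this aromatic carbon in this assay, and it amounts to a 1.6-fold higher number from compound 2 to compound 4 (0.19 log units; within the scatter). The position therefore takes a group with more heavy atoms, a hydrogen-bond acceptor and a three-membered ring without a step beyond the scatter on this read-out. No measured property among those shown bears on this step.

Going by these compounds, the ring nitrogen and the cyclopropyl enter together, so their separate shares stay open, and a plain pyridin-2-yl at this place would begin to divide them. Also open, on these data alone, is whether the same exchange would give a step of this size in the setting of compound 1, whose ring amine differs from that of compound 2.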